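Replacing the 4-methylpiperazin-1-yl group of compound 3

The compounds below may be only part of what the source reports. "The series", "measured", "known", "first", "only" and "open" are said of these compounds alone.

In an ADME assay on microsomes from liver (Homo sapiens) for metabolic stability, read by LC-MS, with a stated time of 10 min (on this read-out higher numbers stand for a more stable compound and lower numbers for a less stable compound), compound 3 `CN1CCN(c2cccc3c2C[C@H](CN(C)[C@H]2CCCc4cccnc42)NC3)CC1` stands lowest of the three measured compounds, at 75.8%. Compound 1 `C[C@@H]1CN(c2cccc3c2C[C@H](CN(C)[C@H]2CCCc4cccnc42)NC3)C[C@H](C)N1` gives 100% and compound 2 `CN(C[C@H]1Cc2c(cccc2N2CCNC(C)(C)C2)CN1)[C@H]1CCCc2cccnc21` gives 100%. Between these two the record shows no change at the digits printed from compound 1 to compound 2 (within the scatter).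

Compound 4 `CN(C[C@H]1Cc2c(cccc2N2C[C@H]3C[C@@H]2CN3)CN1)[C@H]1CCCc2cccnc21` keeps the shared core and alters one group: a group of 7 heavy atoms (5 carbon, 2 nitrogen; 2 five-membered non-aromatic rings with 1 hetero atom each) in place of a group of 7 heavy atoms (5 carbon, 2 nitrogen; one six-membered non-aromatic ring with 2 hetero atoms), on an aromatic carbon.

Within the data shown here, two measured steps bear on this change, as both end in the 4-methylpiperazin-1-yl group that now leaves. They are a number 24.2 percentage points lower from compound 1 to compound 3 (beyond the scatter) and a number 24.2 percentage points lower from compound 2 to compound 3 (beyond the scatter). Read backwards, they point to a higher number once that group is gone. Among the measured compounds shown here, the entering group has no measured precedent, so only part of that size is carried over. A rise beyond the scatter is therefore expected in this assay, smaller than the two measured steps. The expected step is a number 14.2 percentage points higher from compound 3 to compound 4 (beyond the scatter). For compound 4 the estimate is 90%, with an expected range from 70% to 100%.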

Compound 4, percent of the compound remaining: 100%
Estimate against measurement, compound 4: 10 percentage points below; measured number inside the range.
By their numbers in this assay, from the lowest: compound 3; then compounds 1, 2 and 4 (each within the scatter of the next).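

In this assay, the group with 2 five-membered non-aromatic rings replaces 4-methylpiperazin-1-yl on the aromatic carbon with a number 24.2 percentage points higher from compound 3 to compound 4 (beyond the scatter), so a group of the same heavy-atom count, carrying 1 hydrogen-bond donor instead of 0, separates from compound 3 beyond the scatter. Set against the two dimethylpiperazine groups, the same group gives no change at the digits printed from compound 2 to compound 4 (within the scatter) and no change at the digits printed from compound 1 to compound 4 (within the scatter), which shows that a six-membered ring is not required at this position to hold that level. Of the four compounds, only compound 3 stands apart.

On these data alone, with three compounds at one printed number, the read-out does not rank them, and how an unsubstituted piperazin-1-yl or an open-chain diamine would read at this position remains open. No measurement shown offers an explanation for the separation of compound 3 from the other compounds.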